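Ortho-substituted benzyl replaces meta-trifluoromethyl on the piperidine amide

The source may hold more compounds than are shown below. What is called first, only, known or untested is meant among the compounds shown, and "the series" means these compounds.

Compound 2 `O=C(NC1CCN(Cc2cccc(C(F)(F)F)c2)CC1)c1cccc2ccccc12` gives 119 nM in an assay on isolated protein for displacement of a labelled ligand from D(4) dopamine receptor (Homo sapiens) (on this read-out lower numbers stand for stronger inhibition and higher numbers for weaker inhibition), the lowest of the two numbers measured; its nearest neighbour is compound 1 `O=C(NC1CCN(Cc2ccccc2Cl)CC1)c1cccc2ccccc12`, which in this assay gives 329 nM. Among the measured compounds shown here, the only step recorded is a 2.8-fold lower number from compound 1 to compound 2 (0.44 log units; beyond the scatter), a modest change in which 3-(trifluoromethyl)phenyl took the place of 2-chlorophenyl on the saturated chain carbon bound to the amine nitrogen in the ring.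

Compound 3 `Cc1ccccc1CN1CCC(NC(=O)c2cccc3ccccc23)CC1` has not yet been measured. It differs from compound 2 by 2-methylphenyl in place of 3-(trifluoromethyl)phenyl on a saturated chain carbon bound to an amine nitrogen in a ring. The 2-methylphenyl that enters is, by name, closer to the 2-chlorophenyl of compound 1 than to the 3-(trifluoromethyl)phenyl it replaces. For the measured compounds named here, the single measured step therefore bears on it in reverse: going from compound 2 back toward a group resembling that of compound 1 points to a higher number in this assay, of a size near that step, though the direction is inferred from one pair only.

Compound 3 is accordingly expected to give about 280 nM, with a plausible range from 120 nM to 650 nM, which would be a step of a 2.4-fold higher number from compound 2 to compound 3 (0.37 log units; beyond the scatter).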

Compound 3, inhibition constant: 155 nM
The estimate for compound 3 lay 1.8-fold (0.26 log units) above the measured number, and the stated range covers the measured number.
By their numbers in this assay, from the lowest: compounds 2 and 3 (each within the scatter of the next); then compound 1.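

In this assay, the step from the trifluoromethyl group to the methyl group (a 1.3-fold higher number from compound 2 to compound 3 (0.11 log units; within the scatter)) shows that 2-methylphenyl and 3-(trifluoromethyl)phenyl cannot be told apart on this saturated chain carbon, even though the entering group has fewer heavy atoms and carries no fluorine. The other new step, methyl in place of chloro on an aromatic carbon (a 2.1-fold lower number from compound 1 to compound 3 (0.33 log units; beyond the scatter)), is modest but beyond the scatter, so with the place of that group unchanged, its identity alone moves the number, and compound 1 stands apart from both other compounds. Nothing measured here accounts for either step.

The compounds shown leave open whether a methoxy, a nitrile or a fluoro in place of the methyl on an aromatic carbon would stay with compound 3 or fall with compound 1. They also leave open whether the match between compound 2 and compound 3 depends on the group or on where it sits, as 2-methylphenyl and 3-(trifluoromethyl)phenyl differ in both, and how an amine or a carboxylic acid on the phenyl would read.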